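Fluoro on the terminal phenyl of a thienopyrimidine urea

The source may hold more compounds than are shown below. What is called first, only, known or untested is meant among the compounds shown, and "the series" means these compounds.

Measured compounds:
compound 1 `CN(C)CCCNc1nc(-c2ccc(NC(=O)Nc3ccccc3Cl)cc2)nc2ccsc12` — 390 nM
compound 2 `CN(C)CCNc1nc(-c2ccc(NC(=O)Nc3ccccc3)cc2)nc2ccsc12` — 620 nM

Of the compounds shown here, two have been tested in a functional assay on HT-29 cells (Homo sapiens) for cytotoxicity, read by MTT assay, with a stated time of 72 h; a lower number here means a stronger inhibitor, a higher number a weaker inhibitor. Compound 1 gives 390 nM and compound 2 gives 620 nM. Among the compounds with values here, compound 2 therefore has the higher of the two numbers, but its gap to compound 1 lies within the scatter, so the two read as equivalent; they also differ in more than one place, so no single step can be drawn between them.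

Compound 3 `CN(C)CCNc1nc(-c2ccc(NC(=O)Nc3ccc(F)cc3)cc2)nc2ccsc12` has not yet been measured. It differs from compound 2 in one place only: fluoro in place of hydrogen on an aromatic carbon. Nothing in the two measured compounds isolates the effect of this change, so the account expects a step from compound 2 to compound 3 of no size beyond the scatter, in either direction. Compound 3 is thus estimated at 500 nM, with a range of 200 nM to 1500 nM, the expected step being a 1.2-fold lower number from compound 2 to compound 3 (0.09 log units; within the scatter).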

Compound 3, half-maximal inhibitory concentration: 350 nM
Estimate against measurement, compound 3: 1.4-fold (0.15 log units) above, and the stated range covers the measured number.
By their numbers in this assay, from the lowest: compounds 3, 1 and 2 (each within the scatter of the next).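

In this assay, the change from phenyl to 4-fluorophenyl gives a 1.8-fold lower number from compound 2 to compound 3 (0.25 log units; within the scatter), the only step shown that isolates a single change in this series. Fluoro on this aromatic carbon, para to a large group, therefore leaves compound 3 equivalent to compound 2 and does not shift the number beyond the scatter. Nothing shown explains this result or bears on it.

As far as these compounds go, it remains open whether a larger substituent at this position, such as chloro, methoxy or trifluoromethyl, would also stay within the scatter, or whether fluoro on another carbon of the ring would do so. Compound 1 carries both a chloro and a longer amine chain, so the separate contribution of each cannot be read from it.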